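Swapping the Aryl Group on a Shared Core

A few compounds are considered here, and "the series" means these few. Any claim that something is new, unique, unknown or untested is made for them only; others in the source may bear on it.

Measured compounds:
Compound 1, `O=C1N=C(C2C(=O)c3ccccc3C2=O)CC(c2cccc([N+](=O)[O-])c2)N1`: 12%
Compound 2, `O=C1N=C(C2C(=O)c3ccccc3C2=O)CC(c2ccc(Cl)cc2)N1`: 34%

Both compounds were tested in a functional assay on the whole organism for inhibition, with Rattus norvegicus as the target, read by paw edema, with stated times of 30 min and 4 h, at a dose of 10 mg/kg by the oral route; on this read-out higher numbers stand for more inhibition at the one dose given (going by the name of the read-out) and lower numbers for less inhibition. Going by the values given here, compound 2 stands highest of the two numbers, and its nearest neighbour is compound 1; the single measured step is a number 22 percentage points higher from compound 1 to compound 2 (beyond the scatter), a modest rise that lies beyond the scatter.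

Compound 3, `O=C1N=C(C2C(=O)c3ccccc3C2=O)CC(c2ccccc2O)N1`, has not yet been measured. Compared with compound 2 the change is 2-hydroxyphenyl in place of 4-chlorophenyl on a saturated ring carbon.

Among the compounds with values here, only one measured step bears on this change, a number 22 percentage points higher from compound 1 to compound 2 (beyond the scatter), and it concerns a different exchange of the aryl group at the same saturated ring carbon. It shows that swapping that aryl group moves the read-out by a modest amount. Within the data shown here, no measured compound carries 2-hydroxyphenyl, so the direction for compound 3 is uncertain. A modest shift, most likely downward from compound 2, is expected. Compound 3 is expected to give 26%. For compound 3 the expected range runs from 10% to 42%. This estimate means an expected step of a number 8 percentage points lower from compound 2 to compound 3 (within the scatter).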

Compound 3, a percentage reported as inhibition, in the whole organism at one dose (the size of the read-out at that dose, not a potency): 16%
Beside the measured number, compound 3's estimate is 10 percentage points above it, and the stated range covers the measured number.
By their numbers in this assay, from the lowest: compounds 1 and 3 (each within the scatter of the next); then compound 2.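

In this assay the aryl group on the saturated ring carbon now comes in three forms, and replacing 4-chlorophenyl with 2-hydroxyphenyl gives a number 18 percentage points lower from compound 2 to compound 3 (beyond the scatter) on the shared core. Going by these compounds alone, the earlier comparison gave only one exchange, whereas compound 2 now stands clear of both other compounds, so the higher number is not tied to a contrast with 3-nitrophenyl alone. Replacing 3-nitrophenyl with 2-hydroxyphenyl gives a number 4 percentage points higher from compound 1 to compound 3 (within the scatter), so these two quite different aryl groups cannot be told apart on this read-out, even though 2-hydroxyphenyl brings a hydrogen-bond donor that 4-chlorophenyl lacks.

The compounds shown leave open how a plain phenyl ring, or an aryl group carrying an amine or a carboxylic acid, would read in this assay, and so whether the chlorine of compound 2 is what matters at this place or any of several groups would serve as well. Nothing measured here explains why the number changes with the aryl group at this ring carbon.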